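A few compounds are considered here, and "the series" means these few. Any claim that something is new, unique, unknown or untested is made for them only; others in the source may bear on it.

Measured compounds in an assay on cells for binding affinity to Neuropeptide Y receptor type 1 (Homo sapiens); on this read-out higher numbers stand for weaker inhibition and lower numbers for stronger inhibition:
- compound 1, `CCCCOc1cc(CCc2nc(C)c(CC)s2)nc(NCc2cc(Cl)cc(NC(=O)OC(C)C)c2)c1`: 16 nM
- compound 2, `CC/C=C\CCOc1cc(CCc2nc(C)c(CC)s2)nc(NCc2cc(Cl)cc(NC(=O)OC(C)C)c2)c1`: 4.7 nM

Among the compounds with values here, compound 1 stands highest of the two numbers in this assay; its nearest neighbour is compound 2, and the step of a 3.4-fold lower number from compound 1 to compound 2 (0.53 log units; beyond the scatter) is the only measured step. It concerns the same saturated chain carbon, two bonds along the chain from an oxygen on an aromatic ring, that is altered in the compound now at issue.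

Compound 3, `CCc1sc(CCc2cc(OCCc3ccccc3)cc(NCc3cc(Cl)cc(NC(=O)OC(C)C)c3)n2)nc1C`, is not yet measured. Its difference from compound 1 is phenyl in place of ethyl on a saturated chain carbon, two bonds along the chain from an oxygen on an aromatic ring, so the change occurs at the same position as in the step from compound 1 to compound 2, but the entering group is a ring rather than a longer chain. Within the data shown here, the one measured step at this position, a 3.4-fold lower number from compound 1 to compound 2 (0.53 log units; beyond the scatter), was modest and went toward a lower number. On that basis a modest step toward a lower number is expected for compound 3 as well, though with little certainty, as no ring has been tried at this position.

For compound 3 the expected value in this assay is 10 nM, with a range of 3 nM to 35 nM, corresponding to an expected step of a 1.6-fold lower number from compound 1 to compound 3 (0.20 log units; within the scatter).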

Compound 3, half-maximal inhibitory concentration: 30 nM
Estimate against measurement, compound 3: 3.0-fold (0.48 log units) below; measured number inside the range.
By their numbers in this assay, from the lowest: compound 2; then compounds 1 and 3 (each within the scatter of the next).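

In this assay, phenyl in place of ethyl on the saturated chain carbon, two bonds along the chain from an oxygen on an aromatic ring, gives a 1.9-fold higher number from compound 1 to compound 3 (0.27 log units; within the scatter), so the butoxy and phenethyloxy compounds cannot be told apart on this read-out and the ring is accommodated without a change beyond the scatter. The lower number seen with but-1-en-1-yl does not extend to phenyl, as a 6.4-fold higher number from compound 2 to compound 3 (0.81 log units; beyond the scatter) shows, so the outcome at this position depends on which group enters and not simply on replacing ethyl with something larger; among the three compounds, only compound 2 stands apart from the others. Nothing available on these compounds accounts for the difference between the unsaturated chain and the ring.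

The compounds shown do not separate the contribution of chain length from that of the double bond in compound 2, a question that a saturated hexyl chain at the same place would address. On these data alone, how a cyclohexyl group or an amine in place of the phenyl would read in this assay also remains open.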